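Hydrogen for methyl on the ring amine nitrogen

A few compounds are considered here, and "the series" means these few. Any claim that something is new, unique, unknown or untested is made for them only; others in the source may bear on it.

Compound 1 `c1ccc2c(c1)ccn2-c1nc(N2CCNCC2)nc2ccccc12` and compound 2 `CN1CCN(c2nc(-n3ccc4ccccc43)c3ccccc3n2)CC1` share one core; compound 3 `COc1cc(OC)c(-c2nc(N3CCN(C)CC3)nc3ccccc23)c(OC)c1` has another, and the difference between the two cores is not broken down here. In a functional assay on C-33-A cells (Homo sapiens) for antiproliferative activity, read by MTT assay (on this read-out lower numbers stand for stronger inhibition and higher numbers for weaker inhibition), compound 1 gives 8.2 ug/mL, compound 2 gives 11.5 ug/mL and compound 3 gives 50 ug/mL, the highest of the three and beyond the scatter from both others. From compound 2 to compound 1 the change is hydrogen in place of methyl on an amine nitrogen in a ring, with a step of a 1.4-fold lower number from compound 2 to compound 1 (0.15 log units; within the scatter). Compound 4 `COc1cc(OC)c(-c2nc(N3CCNCC3)nc3ccccc23)c(OC)c1` carries the same change, at the same place, on the core of compound 3: hydrogen in place of methyl on an amine nitrogen in a ring. A step of similar size is expected, a 1.3-fold lower number from compound 3 to compound 4 (0.10 log units; within the scatter), because the measured step of a 1.4-fold lower number from compound 2 to compound 1 (0.15 log units; within the scatter) stayed within the scatter. Compound 4 is therefore estimated at 40 ug/mL, between 20 ug/mL and 80 ug/mL.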

Compound 4, half-maximal inhibitory concentration: 50 ug/mL
Beside the measured number, compound 4's estimate is 1.3-fold (0.10 log units) below it; the measured number falls inside the stated range.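

The change from 4-methylpiperazin-1-yl to piperazin-1-yl gives, in this assay, no change at the digits printed from compound 3 to compound 4 (within the scatter). Set beside the earlier step, the change carries from one core to the other with no difference that can be told apart: the same change on two cores in this assay, a 1.4-fold lower number (0.15 log units; within the scatter) from compound 2 to compound 1 and no change at the digits printed (within the scatter) from compound 3 to compound 4, 1.4-fold (0.15 log units) apart, within the scatter of two such steps. Within the data shown here, this shows only that both steps stay within the scatter on these two cores in this one assay; it does not show that the two cores respond identically, or that the same would hold on a third core or in another assay.

Left open is what other groups on that amine nitrogen would do, such as an ethyl group, a longer chain or an acetyl group. Also open, going by these compounds, is whether any of these would shift the number on one core and not on the other.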